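This account rests on a few compounds, and the source may have more. Where it says the series, first, only, none or still open, it means among the compounds named here.

The account follows compound 1 `CC(C)(C)c1cc(NC(=O)[C@@H]2CCCCN2C2CCOCC2)no1` and its relative compound 3 `CC(C)(C)c1cc(NC(=O)[C@@H]2CCCCN2C(=O)N2CCOCC2)no1`, which share one core. Within the data shown here, in an ADME assay (liver) for metabolic stability, with Liver microsome (Homo sapiens) as the target, read by LC-MS, using microsomes and NADPH, tested at 1 uM (on this read-out lower numbers stand for a shorter-lived compound and higher numbers for a longer-lived compound), compound 1 gives 0.317 h, the only plain number among the values shown here. Compound 2 `CC(C)(C)c1cc(NC(=O)[C@@H]2CCCCN2C(=O)C2CCS(=O)(=O)CC2)no1` is the other measured member of the set. In this assay compound 2 gives > 2 h, which is a limit of the assay rather than a number. Compound 2 thus sits at the limit of > 2 h in this assay, at which 1 of the 2 values shown sits. Compound 3 differs from compound 1 in one place: (morpholin-4-yl)carbonyl in place of oxan-4-yl on an amine nitrogen in a ring. Among the measured compounds shown here, no measured pair shows this change directly, so its size cannot be read from a measured step. Compound 3 is expected to be longer-lived than compound 1 in this assay, with an estimated step of a 4.7-fold higher number from compound 1 to compound 3 (0.68 log units; beyond the scatter) that goes beyond the usual scatter. The half-life of compound 3 in this assay is estimated at 1.5 h, with a range from 0.6 h to 4 h.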

Compound 3, half-life: > 2 h
Compound 3 was reported as a limit (the forecaster's own chance of this, stated with the estimate: 35%); middle value at least 1.3-fold (0.12 log units) away from the limit.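

In this assay, (morpholin-4-yl)carbonyl in place of oxan-4-yl on an amine nitrogen in a ring now has a measured effect: an at least 6.3-fold higher number from compound 1 to compound 3 (0.79 log units; beyond the scatter). Among these compounds, this is the first direct pair for this change, and the result for compound 3 is a limit and not a number, so the full size of the step stays unknown. Compound 2 differs from compound 3 on the carbonyl carbon, and the step between them cannot be read, as both results are limits: the limit of > 2 h in this assay, at which 2 of the 3 values shown sit.

The compounds shown therefore leave morpholin-4-yl and 1,1-dioxothian-4-yl unranked on that carbonyl carbon. They also leave open whether the longer half-life goes with the carbonyl or with the morpholin-4-yl ring, a question that a methyl or a dimethylamino group on that carbon could address.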